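This account rests on a few compounds, and the source may have more. Where it says the series, first, only, none or still open, it means among the compounds named here.

Working notes on the series.

Compound 1 `COc1cc(N)c(Cl)cc1C(=O)NC1CCN(CCN2CCCCC2)CC1` gives 100 nM in a functional assay on HEK293 cells for agonist activity at 5-hydroxytryptamine receptor 4 (Homo sapiens), read by cAMP accumulation; on this read-out higher numbers stand for an effect only at larger amounts of compound and lower numbers for an effect already at smaller amounts. Compound 3 `COc1cc(N)c(Cl)cc1C(=O)NC1CCN(CCN2CCN(S(C)(=O)=O)CC2)CC1` carries 4-(methylsulfonyl)piperazin-1-yl in place of piperidin-1-yl on a saturated chain carbon, two bonds along the chain from an amine nitrogen in a ring relative to compound 1, and in this assay compound 3 gives 20 nM; the step is a 5.0-fold lower number from compound 1 to compound 3 (0.70 log units; beyond the scatter). Compound 2 `COc1cc(N)c(Cl)cc1C(=O)NC1CCN(CCCCCCCCN2CCCCC2)CC1` gives 3.16 nM in this assay, the lowest of the three numbers, with its gaps to compound 3 and to compound 1 both beyond the scatter. The difference between the cores of compound 2 and compound 1 is not broken down here.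

Compound 4 `COc1cc(N)c(Cl)cc1C(=O)NC1CCN(CCCCCCCCN2CCN(S(C)(=O)=O)CC2)CC1` is not yet measured in this assay. Relative to compound 2 it carries 4-(methylsulfonyl)piperazin-1-yl in place of piperidin-1-yl on a saturated chain carbon, eight bonds along the chain from an amine nitrogen in a ring. This is the same kind of change as from compound 1 to compound 3, but not the same: in the earlier pair the site is two bonds along the chain from an amine nitrogen in a ring, here eight bonds along the chain.

Among the compounds with values here, from compound 2 to compound 4 in this assay a step of a 2.6-fold lower number from compound 2 to compound 4 (0.42 log units; beyond the scatter) is expected, somewhat smaller than the earlier one, because a 5.0-fold lower number from compound 1 to compound 3 (0.70 log units; beyond the scatter) is the only precedent and sits on a much shorter chain. Compound 4 is estimated at 1.2 nM, within 0.3 nM to 5 nM.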

Compound 4, half-maximal effective concentration: 39.8 nM
Estimate against measurement, compound 4: 33-fold (1.52 log units) below, outside the stated range (above it).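

In this assay, the change from piperidin-1-yl to 4-(methylsulfonyl)piperazin-1-yl with the site eight bonds along the chain gives a 13-fold higher number from compound 2 to compound 4 (1.10 log units; beyond the scatter), so the lower number seen on the core of compound 1 does not carry over to the core of compound 2. The two steps differ in direction as well as size, and the effect of this change therefore cannot be transferred from one of these cores to the other: the same change on two cores in this assay, a 5.0-fold lower number (0.70 log units; beyond the scatter) from compound 1 to compound 3 and a 13-fold higher number (1.10 log units; beyond the scatter) from compound 2 to compound 4, 63-fold (1.80 log units) apart, beyond the scatter of two such steps. Within the data shown here, with only two pairs, this shows that the outcome depends on the core, but not how it varies with chain length or why the direction reverses.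

As far as these compounds go, it remains open whether the step changes gradually or abruptly on a chain of intermediate length, and whether a longer chain would widen the gap. Also open, from the compounds shown here alone, is whether a morpholin-4-yl or 4-acetylpiperazin-1-yl group in the same place would follow the same reversal on the two cores.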